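A few compounds are considered here, and "the series" means these few. Any claim that something is new, unique, unknown or untested is made for them only; others in the source may bear on it.

Measured compounds:
- compound 1 `CCOC(=O)C1=Cc2ccccc2OC1(OCc1cn(CC(=O)NC2CCCCC2)nn1)C(F)(F)F`: 9900 nM
- compound 2 `CCOC(=O)C1=Cc2ccccc2OC1(OCc1cc(-c2ccc3ccccc3c2)no1)C(F)(F)F`: > 150000 nM
- compound 3 `Cc1ccc(-c2cc(COC3(C(F)(F)F)Oc4ccccc4C=C3C(=O)O)on2)cc1`: 51200 nM

In a functional assay on A549 cells (Homo sapiens) for inhibition, read by MTT assay, with a stated time of 24 h (on this read-out lower numbers stand for stronger inhibition and higher numbers for weaker inhibition), compound 1 gives 9900 nM, the lowest of the two numbers shown. Compound 3 gives 51200 nM, a gap beyond the usual scatter. For compound 2 the assay reports only a limit, > 150000 nM, as noted in the limit of > 150000 nM in this assay, at which 1 of the 3 values shown sits. Compound 4 `CCOC(=O)C1=Cc2ccccc2OC1(OCc1cn(-c2ccc(F)c([N+](=O)[O-])c2)nn1)C(F)(F)F` is not yet measured; it differs from compound 1 by 4-fluoro-3-nitrophenyl in place of (cyclohexylcarbamoyl)methyl on an aromatic nitrogen. Among the compounds with values here, no step between two measured compounds shows such a change, so there is nothing here to lean on. Compound 4 is expected to give about 15000 nM, in a range from 4000 nM to 60000 nM. The expected step, a 1.5-fold higher number from compound 1 to compound 4 (0.18 log units; within the scatter), is a modest loss that may well stay within the scatter.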

Compound 4, half-maximal inhibitory concentration: 11900 nM
Beside the measured number, compound 4's estimate is 1.3-fold (0.10 log units) above it, within the range that was stated.
By their numbers in this assay, from the lowest: compounds 1 and 4 (each within the scatter of the next); then compound 3. At a limit, above all of these: compound 2.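

In this assay, this position on the aromatic nitrogen now has its first readable step: a 1.2-fold higher number from compound 1 to compound 4 (0.08 log units; within the scatter). A ring of carbon that is non-aromatic and carried on an amide chain gives way to an aromatic ring bearing fluorine and nitro groups, and the number does not move beyond the scatter. Nothing measured here explains why these two different groups read alike.

On these data alone, whether a plain methyl or a chain ending in an amine on this nitrogen would read the same remains open. So does the separate contribution of the fluorine and the nitro group in compound 4.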